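The compounds below may be only part of what the source reports. "The series", "measured", "known", "first", "only" and "open" are said of these compounds alone.

Compound 1 `NC1CCC(Nc2nc(NCc3ccc(Br)cc3)c3ncn(C4CCCC4)c3n2)CC1`: 995 nM
Compound 2 `NC1CCC(Nc2nc(NCc3ccc(-c4ccco4)nc3)c3ncn(C4CCCC4)c3n2)CC1`: 44 nM

Among the measured compounds shown here, in a functional assay on HOS cells (Homo sapiens) for inhibition, with a stated time of 72 h (on this read-out lower numbers stand for stronger inhibition and higher numbers for weaker inhibition), compound 2 holds the lower of these two numbers, and the only measured step, a 23-fold lower number from compound 1 to compound 2 (1.35 log units; beyond the scatter), is large. Compound 3 `NC1CCC(Nc2nc(NCc3ccc(-c4ccccc4O)nc3)c3ncn(C4CCCC4)c3n2)CC1` keeps the core of compound 2 and differs in one place: 2-hydroxyphenyl in place of furan-2-yl on an aromatic carbon. No measured step alters this same spot, so nothing shown bears directly on the change; the large step just named only shows that this region of the molecule can move the number strongly. A modest shift, possibly within the scatter, is expected for compound 3, a 1.4-fold higher number from compound 2 to compound 3 (0.13 log units; within the scatter). Compound 3 is therefore estimated at 60 nM, within 20 nM to 200 nM.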

Compound 3, half-maximal inhibitory concentration: 14 nM
For compound 3 the middle estimate is 4.3-fold (0.63 log units) above the measured one; measured number outside the range, below it.
By their numbers in this assay, from the lowest: compound 3; then compound 2; then compound 1.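

In this assay, replacing furan-2-yl with 2-hydroxyphenyl on the aromatic carbon next to the ring nitrogen gives a 3.1-fold lower number from compound 2 to compound 3 (0.50 log units; beyond the scatter) and is a modest step, but beyond the scatter. This spot itself can therefore shift the number, and a six-membered carbon ring carrying a hydrogen-bond donor is accepted there. No measurement available here explains the shift. The change alters ring size, ring type and donor count together, so the compounds shown cannot separate these. A plain phenyl or 2-aminophenyl at this spot would help to tell them apart.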